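The source may report more compounds than this note shows. Statements on the series, on what has been measured and on what is new or still open speak of the compounds shown alone.

Compound 1: `O=S(=O)(NCCCNCc1cccc2ccccc12)c1cc(C(F)(F)F)cc(C(F)(F)F)c1` in a functional assay on A2780 cells (Homo sapiens) for inhibition, read by MTT assay, with a stated time of 72 h (a higher number here means a weaker inhibitor of growth, a lower number a stronger inhibitor of growth), gives 3100 nM.
Compound 2: `O=S(=O)(NCCCNCc1cccc(Cl)c1)c1cc(C(F)(F)F)cc(C(F)(F)F)c1` in this assay gives 2200 nM.
Compound 3: `O=S(=O)(NCCCNCc1ccc(-c2ccccc2)cc1)c1cc(C(F)(F)F)cc(C(F)(F)F)c1` in this assay gives 2600 nM.

All three share the same core and differ only in the aromatic group carried on a saturated chain carbon bound to an amine nitrogen. Compound 1 sits at the top of the three numbers, yet its gap to compound 3 and its gap to compound 2 both lie within the usual scatter, so no ordering among them can be trusted.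

The unmeasured compound 4 is `O=S(=O)(NCCCNCc1ccccc1)c1cc(C(F)(F)F)cc(C(F)(F)F)c1`. It is made from compound 1 by this change: phenyl in place of naphthalen-1-yl on a saturated chain carbon bound to an amine nitrogen.

For the measured compounds named here, the only measured step at the same place is the one from compound 1 to compound 2, which swapped in a different single ring, and it read a 1.4-fold lower number from compound 1 to compound 2 (0.15 log units; within the scatter). That step stayed inside the scatter, and the step from compound 1 to compound 3, which changed the same position, shows two values also within the scatter of each other. Given that the ring swaps seen so far moved nothing beyond the noise, compound 4 is expected to land close to compound 1, with a step of a 1.1-fold higher number from compound 1 to compound 4 (0.05 log units; within the scatter) that need not exceed the scatter.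

Compound 4 is therefore estimated at 3500 nM, within a range from 1500 nM to 8000 nM.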

Compound 4, concentration for 50% growth inhibition: 4900 nM
Estimate against measurement, compound 4: 1.4-fold (0.15 log units) below, and the stated range covers the measured number.
By their numbers in this assay, from the lowest: compounds 2, 3, 1 and 4 (each within the scatter of the next, the first and the last beyond it).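

In this assay, going from naphthalen-1-yl to phenyl on a saturated chain carbon bound to an amine nitrogen gives a 1.6-fold higher number from compound 1 to compound 4 (0.20 log units; within the scatter), so the loss of one of the two aromatic rings cannot be told from noise. Removing the outer phenyl gives a 1.9-fold higher number from compound 3 to compound 4 (0.28 log units; within the scatter) and so also stays inside the scatter, while hydrogen in place of chloro gives a 2.2-fold higher number from compound 2 to compound 4 (0.35 log units; beyond the scatter), a modest step and the first in this series to pass beyond the scatter, showing that the plain phenyl compound can be told apart from the chloro compound but not from the two larger aromatic compounds. No supporting measurement is available to explain these differences.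

As far as these compounds go, all four compounds carry a purely carbon aromatic group with or without one chloro, so it remains open whether a pyridine ring, a hydroxyl, a carboxylic acid or a second amine at this place would move the number well beyond the scatter. From the compounds shown here alone, it also remains open whether a longer chain would leave the number this flat.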